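Methylating the phenol: from compound 2 to compound 4

A few compounds are considered here, and "the series" means these few. Any claim that something is new, unique, unknown or untested is made for them only; others in the source may bear on it.

Measured compounds:
compound 1 `O=C(Nc1cccc(-n2cc(-c3ccncc3)c(-c3cc(O)cc(Cl)c3)n2)c1)Nc1ccc(Cl)c(C(F)(F)F)c1`: 107%
compound 2 `O=C(Nc1cccc(-n2cc(-c3ccncc3)c(-c3cc(O)cc(Cl)c3)n2)c1)Nc1ccc(Cl)c(Cl)c1`: 52%
compound 3 `COc1cc(Cl)cc(-c2nn(-c3cccc(NC(=O)Nc4cc(C(F)(F)F)cc(C(F)(F)F)c4)c3)cc2-c2ccncc2)c1`: 100%

In a functional assay on NCI-H322M cells (Homo sapiens) for inhibition, read by sulforhodamine B assay, with a stated time of 48 h, tested at 0.01 uM (a higher number here means a weaker effect of the compound at the concentration tested, a lower number a stronger effect), compound 2 stands lowest of the three numbers, beyond the scatter from both compound 3 and compound 1. Within the data shown here, the one measured step, a number 55 percentage points lower from compound 1 to compound 2 (beyond the scatter), concerns the urea end of the molecule, not the phenol.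

Compound 4 `COc1cc(Cl)cc(-c2nn(-c3cccc(NC(=O)Nc4ccc(Cl)c(Cl)c4)c3)cc2-c2ccncc2)c1` differs from compound 2 by methyl in place of hydrogen on an oxygen on an aromatic ring. Among the measured compounds shown here, no measured step covers this change. Compound 3 carries the methoxy but also a different urea end, so its value only hints. Compound 4 is expected to lose some effect, a step of a number 23 percentage points higher from compound 2 to compound 4 (beyond the scatter), giving an estimate of 75%, between 45% and 105%.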

Compound 4, a percentage reported as activity, at one concentration (the size of the read-out at that concentration, not a potency): 101%
Estimate against measurement, compound 4: 26 percentage points below, and the stated range covers the measured number.
By their numbers in this assay, from the lowest: compound 2; then compounds 3, 4 and 1 (each within the scatter of the next).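

In this assay, turning the hydroxy into a methoxy on the 3-chloro-5-hydroxyphenyl group gives a number 49 percentage points higher from compound 2 to compound 4 (beyond the scatter), so this small change alone is enough to weaken the effect greatly. Among these compounds, this is the first direct reading of the change, with the urea end held constant, which compound 3 could not provide. Nothing available explains the loss.

The compounds shown leave open how an amine or an ethoxy group would read at this place. They also leave open whether methylating the hydroxy acts alike with the urea end of compound 1.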